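Removing the Carboxy Group on a Thiophene Core

The source may hold more compounds than are shown below. What is called first, only, known or untested is meant among the compounds shown, and "the series" means these compounds.

Measured compounds:
- compound 1, `COc1ccc(-c2sc(C(=O)O)cc2-c2cc(OC)c(OC)c(OC)c2)cc1[N+](=O)[O-]`, 37200 nM
- compound 2, `COc1cc(-c2cc(C(=O)O)sc2-c2ccc3ccccc3c2)cc(OC)c1OC`, 13400 nM
- compound 3, `COc1ccc(-c2sccc2-c2cc(OC)c(OC)c(OC)c2)cc1[N+](=O)[O-]`, 2100 nM

All three were tested in a functional assay on HT-1080 cells (Homo sapiens) for antiproliferative activity, read by MTT assay, with a stated time of 72 h; a higher number here means a weaker inhibitor, a lower number a stronger inhibitor. Compound 3 differs from compound 1 by one change, (hydrogen in place of carboxy on an aromatic carbon), and this gave an 18-fold lower number from compound 1 to compound 3 (1.25 log units; beyond the scatter). Compound 2 shares the change site but differs from compound 1 elsewhere; the difference between the two cores is not broken down here. Compound 4, `COc1cc(-c2ccsc2-c2ccc3ccccc3c2)cc(OC)c1OC`, is not yet measured. It differs from compound 2 by hydrogen in place of carboxy on an aromatic carbon, the same kind of change as from compound 1 to compound 3, although the surroundings differ: in compound 4 the place lies two ring bonds from the ring atom that bears a naphthalen-2-yl group rather than from two ring atoms that each bear a large group. Resting on the drop seen in an 18-fold lower number from compound 1 to compound 3 (1.25 log units; beyond the scatter), compound 4 is expected to show a similarly large step, a 15-fold lower number from compound 2 to compound 4 (1.17 log units; beyond the scatter). Compound 4 is therefore estimated at 900 nM in this assay, likely between 300 nM and 3000 nM.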

Compound 4, half-maximal inhibitory concentration: 5430 nM
Compound 4: middle estimate off by 6.0-fold (0.78 log units), on the low side, outside the stated range (above it).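

Removing the carboxy group lowers the number on the second core as well, with a 2.5-fold lower number from compound 2 to compound 4 (0.39 log units; beyond the scatter) in this assay, so the direction of the step carries over from the core of compound 1 to the core of compound 2. The size of the step does not carry over, as the two steps lie further apart than repeated measurements would scatter: the same change on two cores in this assay, an 18-fold lower number (1.25 log units; beyond the scatter) from compound 1 to compound 3 and a 2.5-fold lower number (0.39 log units; beyond the scatter) from compound 2 to compound 4, 7.2-fold (0.86 log units) apart, beyond the scatter of two such steps. Among the compounds shown here, with only two cores, this does not show why the size differs, or how the same change would behave on any other core.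

As far as these compounds go, it remains open whether a methyl ester or a primary amide in place of the carboxy group would behave like hydrogen on either core. Also open, from the compounds shown here alone, is what a single change elsewhere on these cores, such as replacing the naphthalen-2-yl group, would do.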